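A few compounds are considered here, and "the series" means these few. Any claim that something is new, unique, unknown or untested is made for them only; others in the source may bear on it.

Among the compounds with values here, compound 1 `Cc1cccc(NS(=O)(=O)c2ccc(N3CCNC3=O)cc2)c1` gives 69 nM in a functional assay on M21 cells (Homo sapiens) for antiproliferative activity, read by sulforhodamine B assay, with a stated time of 48 h (a higher number here means a weaker inhibitor, a lower number a stronger inhibitor), the lowest of the three numbers measured so far. Compound 2 `O=C1NCCN1c1ccc(S(=O)(=O)Nc2ccc(I)cc2)cc1` gives 260 nM, and compound 3 `COc1ccc(NS(=O)(=O)c2ccc(N3CCNC3=O)cc2)cc1OC` gives 340 nM. Within the data shown here, the only single change measured is a 3.8-fold higher number from compound 1 to compound 2 (0.58 log units; beyond the scatter), which swaps the whole ring on the sulfonamide nitrogen rather than adding one small group. Compound 4 `Cc1ccc(C)c(NS(=O)(=O)c2ccc(N3CCNC3=O)cc2)c1` differs from compound 1 by methyl in place of hydrogen on an aromatic carbon. Among the measured compounds shown here, no measured step matches adding a methyl to this ring, so little can be inferred beyond the fact that changing the substituents on this ring did shift the numbers in the step to compound 2. The number for compound 4 is therefore expected to sit close to that of compound 1, estimated at 90 nM, between 35 nM and 230 nM, a step of a 1.3-fold higher number from compound 1 to compound 4 (0.12 log units; within the scatter).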

Compound 4, half-maximal inhibitory concentration: 27 nM
Compound 4: the middle estimate sits 3.3-fold (0.52 log units) above what was measured; measured number outside the range, below it.
By their numbers in this assay, from the lowest: compound 4; then compound 1; then compounds 2 and 3 (each within the scatter of the next).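

In this assay, going from 3-methylphenyl to 2,5-dimethylphenyl gives a 2.6-fold lower number from compound 1 to compound 4 (0.41 log units; beyond the scatter) and shows that this ring carbon, ortho to a large group and para to a methyl group, can take one extra methyl with the number falling. The ring swap gives a 9.6-fold lower number from compound 2 to compound 4 (0.98 log units; beyond the scatter) and puts the 2,5-dimethylphenyl ring well ahead of the 4-iodophenyl ring. Nothing available explains why the methyl lowers the number. Still open, on these data alone, is whether an ethyl group, a chlorine atom or an amine on this same carbon would do the same, and whether this methyl would lower the number without the other methyl on the ring.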